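Series notes: compound 3 to compound 4 in cytotoxicity

The source may hold more compounds than are shown below. What is called first, only, known or untested is meant among the compounds shown, and "the series" means these compounds.

In an ADME assay on SH-SY5Y cells (Homo sapiens) for cytotoxicity, read by MTT assay, with a stated time of 48 h (a higher number here means a weaker inhibitor, a lower number a stronger inhibitor), compound 1 `COc1ccc(C(=O)/C=C/c2ccc(OCc3ccccc3)cc2)c(O)c1` gives > 100000 nM, which is a limit of the assay and not a number. Compound 2 `COc1ccc(C(=O)/C=C/c2ccc(C(=O)N3CCCC3)cc2)c(O)c1` gives > 100000 nM in this assay, again only a limit. Compound 3 `COc1ccc(C(=O)/C=C/c2ccc(C(=O)N3CCCCC3)cc2)c(O)c1` likewise gives > 100000 nM, a limit. The steps a step that the two limits leave unreadable from compound 1 to compound 2, a step that the two limits leave unreadable from compound 1 to compound 3 and a step that the two limits leave unreadable from compound 2 to compound 3 are therefore unreadable, since (the limit of > 100000 nM in this assay, at which 3 of the 3 values shown sit). Compound 3 thus stands at the limit shared by all three values shown. Compound 4 `COC(=O)c1ccc(/C=C/C(=O)c2ccc(OC)cc2O)cc1` differs from compound 3 by methoxy in place of piperidin-1-yl on a carbonyl carbon. Among the measured compounds shown here, no measured step bears directly on this change, and none of the three carries a readable size. The expectation for compound 4 is therefore a step that the limit leaves unreadable from compound 3 to compound 4, most likely another limit, with the estimate 150000 nM between 60000 nM and 400000 nM.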

Compound 4, half-maximal inhibitory concentration: > 100000 nM
Compound 4 ended at the assay's limit; the forecaster's own chance of this, stated with the estimate: 80%; the middle value lies beyond the limit too.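

No new step can be read among compound 1, compound 2, compound 3 and compound 4 in this assay, since all four share one limit: the limit of > 100000 nM in this assay, at which 4 of the 4 values shown sit.

The compounds shown leave open how large any of these changes is, and where half-maximal inhibition would fall for any of the four.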